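Swapping a Methoxy for Phenyl on a Shared Core

The source may report more compounds than this note shows. Statements on the series, on what has been measured and on what is new or still open speak of the compounds shown alone.

Of the compounds shown here, three sharing one core have been tested in a functional assay on CHO cells for agonist activity at muscarinic acetylcholine receptor M5 (Homo sapiens), read by calcium flux; on this read-out higher numbers stand for an effect only at larger amounts of compound and lower numbers for an effect already at smaller amounts. Compound 1 `O=C1C(=O)N(Cc2ccc(-c3ccc(F)nc3)cc2)c2ccc(OC(F)(F)F)cc21` gives 3600 nM, compound 2 `Cn1cc(-c2ccc(CN3C(=O)C(=O)c4cc(OC(F)(F)F)ccc43)cc2)cn1` gives 3300 nM, and compound 3 `COc1ccc(CN2C(=O)C(=O)c3ccc(OC(F)(F)F)cc32)cc1` gives 5700 nM, the highest of the three numbers, though both gaps lie within the scatter. Among the compounds with values here, the only step between neighbours, a 1.1-fold lower number from compound 1 to compound 2 (0.04 log units; within the scatter), exchanged one aryl group for another. Compound 4 `O=C1C(=O)N(Cc2ccc(-c3ccccc3)cc2)c2cc(OC(F)(F)F)ccc21` differs from compound 3 by phenyl in place of methoxy on an aromatic carbon. Within the data shown here, no measured step replaces a methoxy by an aryl group, so the aryl-bearing compounds 1 and 2 are the only guide, and their values sit close to that of compound 3. In this assay, compound 4 is therefore expected to show a 1.6-fold lower number from compound 3 to compound 4 (0.21 log units; within the scatter), giving an estimated 3500 nM, within a range from 1200 nM to 10000 nM.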

Compound 4, half-maximal effective concentration: 2700 nM
Compound 4: the middle estimate sits 1.3-fold (0.11 log units) above what was measured; the measured number falls inside the stated range.
By their numbers in this assay, from the lowest: compounds 4, 2, 1 and 3 (each within the scatter of the next, the first and the last beyond it).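

Replacing methoxy with phenyl on this aromatic carbon, para to a large group, gives a 2.1-fold lower number from compound 3 to compound 4 (0.32 log units; beyond the scatter) in this assay. This is the first listed step to pass the usual scatter, and it shows that this position tolerates a full aromatic ring in place of the small methoxy, with the number falling rather than rising. Nothing available explains this modest shift. Going by these compounds, the result rests on a single pair, so it remains open whether a morpholine, a carboxylic acid or a longer alkyl chain at this position would lower the number further or raise it.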